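Ethyl to isopropyl on the aromatic nitrogen

This account rests on a few compounds, and the source may have more. Where it says the series, first, only, none or still open, it means among the compounds named here.

Measured so far in a functional assay on MKN-45 cells (Homo sapiens) for inhibition, with a stated time of 72 h; a lower number here means a stronger inhibitor, a higher number a weaker inhibitor
- compound 1 `COc1cc(C(=O)c2cccc3c2ccn3C)cc(OC)c1OC` gives 21.6 nM
- compound 2 `COc1cc(C(=O)c2ccc3c(ccn3C)c2)cc(OC)c1OC` gives 11.2 nM
- compound 3 `CCn1ccc2cc(C(=O)c3cc(OC)c(OC)c(OC)c3)ccc21` gives 31 nM

Compound 3 lies within the scatter of compound 1 and beyond the scatter above compound 2. Compound 4 `COc1cc(C(=O)c2ccc3c(ccn3C(C)C)c2)cc(OC)c1OC` carries isopropyl where compound 3 carries ethyl (methyl in place of hydrogen on a saturated chain carbon bound to an aromatic nitrogen and a saturated chain carbon). Within the data shown here, one measured step bears on this (a 2.8-fold higher number from compound 2 to compound 3 (0.44 log units; beyond the scatter)), a modest one that is likewise methyl in place of hydrogen on a saturated chain carbon bound to an aromatic nitrogen. In this assay a further step of similar size is expected, toward a higher number, though it rests on that single precedent. The estimated step reads a 2.3-fold higher number from compound 3 to compound 4 (0.35 log units; beyond the scatter) in this series. Compound 4 is expected at 70 nM (estimated range 30 nM to 170 nM).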

Compound 4, half-maximal inhibitory concentration: 470 nM
The estimate for compound 4 lay 6.7-fold (0.83 log units) below the measured number, and the stated range ends below it.
By their numbers in this assay, from the lowest: compounds 2, 1 and 3 (each within the scatter of the next, the first and the last beyond it); then compound 4.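

Adding a second methyl on the saturated chain carbon bound to the aromatic nitrogen has a much larger effect than the first added methyl did: ethyl to isopropyl gives a large step (a 15-fold higher number from compound 3 to compound 4 (1.18 log units; beyond the scatter)) in this assay, where methyl to ethyl gave only a modest one (a 2.8-fold higher number from compound 2 to compound 3 (0.44 log units; beyond the scatter)). Overall, isopropyl in place of methyl on the aromatic nitrogen gives a large loss (a 42-fold higher number from compound 2 to compound 4 (1.62 log units; beyond the scatter)), so the two added methyl groups do not contribute equally. No available evidence accounts for this step.

Still open, going by these compounds, is whether propyl, a longer chain, tracks ethyl or isopropyl, which would separate chain length from branching. Cyclopropyl on the aromatic nitrogen would test the same question.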